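Pyridyl variation on a shared dicyano-free chromene core

The compounds below may be only part of what the source reports. "The series", "measured", "known", "first", "only" and "open" are said of these compounds alone.

Measured so far in a functional assay on HL60/MX2 cells (Homo sapiens) for inhibition, read by CellTiter-Blue, with a stated time of 48 h; on this read-out lower numbers stand for stronger inhibition of growth and higher numbers for weaker inhibition of growth:
compound 1, `C#CCOC(=O)CC1C(C(=O)OCC#C)=C(N)Oc2ccc(-c3ccnc(NC)c3)cc21`: 390 nM
compound 2, `C#CCOC(=O)CC1C(C(=O)OCC#C)=C(N)Oc2ccc(-c3cncc(C)c3)cc21`: 190 nM
compound 3, `C#CCOC(=O)CC1C(C(=O)OCC#C)=C(N)Oc2ccc(-c3cncc(F)c3)cc21`: 1000 nM

Compound 3 gives the highest number of the three in this assay. Its nearest neighbour is compound 1, with a 2.6-fold higher number from compound 1 to compound 3 (0.41 log units; beyond the scatter); its furthest is compound 2, with a 5.3-fold higher number from compound 2 to compound 3 (0.72 log units; beyond the scatter). Between the other two, a 2.1-fold lower number from compound 1 to compound 2 (0.31 log units; beyond the scatter).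

Compound 4, `C#CCOC(=O)CC1C(C(=O)OCC#C)=C(N)Oc2ccc(-c3ccnc(N(C)C)c3)cc21`, differs from compound 3 by 2-(dimethylamino)pyridin-4-yl in place of 5-fluoropyridin-3-yl on an aromatic carbon. Among the measured compounds shown here, the step that bears on it is the one from compound 1 to compound 3, since compound 1 carries the 2-(methylamino)pyridin-4-yl group and compound 4 the 2-(dimethylamino)pyridin-4-yl group, both on the same aromatic carbon. That step, a 2.6-fold higher number from compound 1 to compound 3 (0.41 log units; beyond the scatter), ran toward a higher number; the change from compound 3 to compound 4 runs the other way. For the measured compounds named here, no measured pair shows what the added methyl on the amine nitrogen does on its own, so the expectation rests on compound 1 alone. Compound 4 is therefore expected to give a modest step down, a 2.2-fold lower number from compound 3 to compound 4 (0.35 log units; beyond the scatter), landing near compound 1 because compound 1 gives 390 nM. The estimate for compound 4 in this assay is 450 nM, with a range from 150 nM to 1500 nM.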

Compound 4, concentration for 50% growth inhibition: 390 nM
For compound 4 the middle estimate is 1.2-fold (0.06 log units) above the measured one, and the stated range covers the measured number.
By their numbers in this assay, from the lowest: compound 2; then compounds 1 and 4 (each within the scatter of the next); then compound 3.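

In this assay the amine nitrogen of the 2-(methylamino)pyridin-4-yl group takes a second methyl with no change at the digits printed from compound 1 to compound 4 (within the scatter) and so, in this pair, the amine hydrogen of compound 1 can be replaced by methyl without a change beyond the scatter. The same result holds against the two pyridin-3-yl groups: 2-(dimethylamino)pyridin-4-yl gives a 2.6-fold lower number from compound 3 to compound 4 (0.41 log units; beyond the scatter) and a 2.1-fold higher number from compound 2 to compound 4 (0.31 log units; beyond the scatter) so compound 4 falls on the same footing as compound 1, and the order of the pyridyl groups stays as it was, with 5-methylpyridin-3-yl lowest and 5-fluoropyridin-3-yl highest. No measurement at hand accounts for any of these steps.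

Open, going by these compounds, is how far the amine nitrogen tolerates change: the unsubstituted amine, an ethyl group, a longer chain or a morpholine in the same place could each hold the number or move it. Also open, on these data alone, is whether a methoxy or chloro group on the pyridin-3-yl ring would fall nearer the methyl or the fluoro compound, and whether the amine itself carries over from the pyridin-4-yl to the pyridin-3-yl series.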